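Hydroxymethyl in place of methyl on compound 3

This account rests on a few compounds, and the source may have more. Where it says the series, first, only, none or still open, it means among the compounds named here.

Values so far from an ADME assay on HepG2 cells (Homo sapiens) for cytotoxicity, read by MTT assay, with a stated time of 24 h (a higher number here means that more compound is tolerated, a lower number that less compound is tolerated), are these
compound 1 (`CC1Cn2c(nc([N+](=O)[O-])c2-c2ccc(CO)cc2)O1`) gives > 500000 nM as a limit
compound 2 (`CC1Cn2c(nc([N+](=O)[O-])c2-c2cccc(C#N)c2)O1`) gives > 500000 nM as a limit
compound 3 (`Cc1ccc(C#Cc2c([N+](=O)[O-])nc3n2CC(C)O3)cc1`) gives 4440 nM as a number

Among the three values, compound 3 holds the only number (4440 nM). The other two are limits. Compound 4 (`CC1Cn2c(nc([N+](=O)[O-])c2C#Cc2ccc(CO)cc2)O1`) differs from compound 3 by hydroxy in place of hydrogen on a saturated chain carbon bound to an aromatic carbon, read also as methyl to hydroxymethyl. For the measured compounds named here, no measured pair shows this change alone. Compound 1 also carries hydroxymethyl and stands at a limit (> 500000 nM). Compound 2 lacks it and stands at a limit too (> 500000 nM). The hint is therefore weak, and only a modest expected shift toward more compound tolerated in this assay is estimated (a 3.4-fold higher number from compound 3 to compound 4 (0.53 log units; beyond the scatter)). Compound 4 is estimated at 15000 nM within an expected range (4000 nM to 80000 nM).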

Compound 4, half-maximal cytotoxic concentration: 9000 nM
Compound 4: the middle estimate sits 1.7-fold (0.22 log units) above what was measured; measured number inside the range.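

In this assay, for the compounds shown here, methyl to hydroxymethyl can now be read alone for the first time, as a 2.0-fold higher number from compound 3 to compound 4 (0.31 log units; beyond the scatter). This single added hydroxy thus has a measurable effect on this carbon, though a modest one, and compound 4 remains a number rather than a limit. The other compounds offer no such reading of the change: the limit of > 500000 nM in this assay, at which 2 of the 4 values shown sit.

On these data alone, whether a carboxylic acid, an amine or a longer chain in place of hydroxymethyl would move the number further remains open. So does whether the same change would give a similar step on another compound.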